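Ethyl to cyano step in the series

The compounds below may be only part of what the source reports. "The series", "measured", "known", "first", "only" and "open" are said of these compounds alone.

In a functional assay (aorta) with Oryctolagus cuniculus as the target (on this read-out lower numbers stand for tighter binding and higher numbers for weaker binding), compound 3 `CCc1ccc(OCCCN2CCC(C(c3ccc(F)cc3)c3ccc(F)cc3)CC2)c(OC)c1` gives 2.51 nM and sits level with compound 1 `COc1cc(C(C)=O)ccc1OCCCN1CCC(C(c2ccc(F)c(F)c2)c2ccc(F)c(F)c2)CC1` at 2.51 nM in these readings. Compound 2 `COc1cc(C(C)=O)ccc1OCCCN1CCC(C(c2ccc(F)cc2)C2CCCCC2)CC1` gives 5.01 nM and stays within the scatter of both. Compound 4 `COc1cc(C#N)ccc1OCCCN1CCC(C(c2ccc(F)cc2)c2ccc(F)cc2)CC1` carries cyano in place of ethyl on an aromatic carbon, para to a large group cyano in place of ethyl on an aromatic carbon and is otherwise the same as compound 3. Within the data shown here, no measured pair isolates this change. Compound 1 differs from compound 3 at that carbon and elsewhere, yet compound 1 at 2.51 nM shows no gap from compound 3 at 2.51 nM in this assay so only a small move is expected. The expected step is a 1.4-fold higher number from compound 3 to compound 4 (0.14 log units; within the scatter) and it is not expected to pass beyond the scatter. For compound 4 the estimated value is 3.5 nM with an expected range from 1.2 nM to 10 nM in this assay as a working figure.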

Compound 4, dissociation constant: 2 nM
The estimate for compound 4 lay 1.8-fold (0.24 log units) above the measured number, within the range that was stated.
By their numbers in this assay, from the lowest: compounds 4, 1, 3 and 2 (each within the scatter of the next, the first and the last beyond it).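

In this assay, among these compounds, cyano in place of ethyl on this aromatic carbon, para to a large group, gives a 1.3-fold lower number from compound 3 to compound 4 (0.10 log units; within the scatter), and this is the first pair that isolates the position. With the rest of the structure held constant, ethyl and cyano cannot be told apart here, although the change adds a triple bond and a hydrogen-bond acceptor.

From the compounds shown here alone, whether this carbon also accepts an amine or a carboxylic acid remains open. So does whether the same swap would read alike on the core of compound 2. No supporting data on hand bear on this result.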